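Swapping the Benzyl Group: An Expected Loss of Cytotoxicity

The source may hold more compounds than are shown below. What is called first, only, known or untested is meant among the compounds shown, and "the series" means these compounds.

Compound 1 `Cc1ccccc1Cn1cc(COc2ccc3c(=O)ccoc3c2)nn1` gave in a functional assay on A549 cells (Homo sapiens) for cytotoxicity, read by MTT assay, with a stated time of 48 h (on this read-out higher numbers stand for weaker inhibition and lower numbers for stronger inhibition), only a limit, > 100000 nM.
Compound 2 `O=c1ccoc2cc(OCc3cn(Cc4ccc(Cl)cc4Cl)nn3)ccc12` gave in this assay 5260 nM.
Compound 3 `N#Cc1ccc(Cn2cc(COc3ccc4c(=O)ccoc4c3)nn2)cc1` gave in this assay only a limit, > 100000 nM.

Going by the values given here, compound 2 is thus the only one with a number; the other two sit at the limit of > 100000 nM in this assay, at which 2 of the 3 values shown sit. Compound 4 `N#Cc1cccc(Cn2cc(COc3ccc4c(=O)ccoc4c3)nn2)c1` differs from compound 2 in one place: 3-cyanophenyl in place of 2,4-dichlorophenyl on a saturated chain carbon bound to an aromatic nitrogen. The closest measured step is an at least 19-fold higher number from compound 2 to compound 3 (1.27 log units; beyond the scatter), where a cyanophenyl also replaced the 2,4-dichlorophenyl. A comparable large rise in the number is therefore expected for compound 4, likely ending at or near the limit. Compound 4 is estimated at 60000 nM, within 15000 nM to 250000 nM, which means an expected step of an 11-fold higher number from compound 2 to compound 4 (1.06 log units; beyond the scatter).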

Compound 4, half-maximal inhibitory concentration: 14300 nM
Compound 4: the middle estimate sits 4.2-fold (0.62 log units) above what was measured, and the stated range ends above it.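

The change from 2,4-dichlorobenzyl to 3-cyanobenzyl brings only a 2.7-fold higher number from compound 2 to compound 4 (0.43 log units; beyond the scatter), so a cyanophenyl on this chain carbon does not by itself abolish activity in this assay. The place of the nitrile on the ring matters, with an at least 6.9-fold lower number from compound 3 to compound 4 (0.84 log units; beyond the scatter), and the 3-cyanophenyl also reads better than the 2-methylphenyl, with an at least 6.9-fold lower number from compound 1 to compound 4 (0.84 log units; beyond the scatter). These last two steps start from a limit, not a true number: the limit of > 100000 nM in this assay, at which 2 of the 4 values shown sit.

Still open, on these data alone, is how an amine or a carboxylic acid on this aromatic ring would read, and whether a longer chain in place of the single chain carbon would keep this activity.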